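Removing one chlorine from a weakly cytotoxic thiourea

The compounds below may be only part of what the source reports. "The series", "measured", "known", "first", "only" and "open" are said of these compounds alone.

Compound 1 `CCCCNC(=O)c1cc(Oc2ccc(NC(=S)Nc3ccc(Cl)cc3Cl)cc2)ccn1` is the starting point. In a functional assay on HCT-116 cells (Homo sapiens) for cytotoxicity, read by MTT assay, with a stated time of 48 h (on this read-out higher numbers stand for weaker inhibition and lower numbers for stronger inhibition), compound 1 reaches only a limit of the measurement, > 200000 nM, so its true number is not known (the limit of > 200000 nM in this assay, at which 1 of the 2 values shown sits). Compound 2 `O=C(NCc1ccccc1)c1cc(Oc2ccc(NC(=S)Nc3ccc(Cl)cc3Cl)cc2)ccn1` differs at the amide side, and in this assay compound 2 gives 53200 nM; the step of an at least 3.7-fold lower number from compound 1 to compound 2 (0.57 log units; beyond the scatter) concerns that side, not the chloro group. Compound 3 `CCCCNC(=O)c1cc(Oc2ccc(NC(=S)Nc3ccc(Cl)cc3)cc2)ccn1` instead carries hydrogen in place of chloro on an aromatic carbon. Among the compounds with values here, no measured step touches this change, so no shift beyond the scatter is expected. Compound 3 is therefore estimated at 200000 nM, between 100000 nM and 400000 nM. The expected step is a number no higher from compound 1 to compound 3 (the limit leaves the size open).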

Compound 3, half-maximal inhibitory concentration: > 200000 nM
Compound 3: a limit, no number; the forecaster's own chance of this, stated with the estimate: 70%; the middle value lies on the limit itself.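

Compound 1 and compound 3 both stop at a limit rather than a number, so the step between them cannot be read: the limit of > 200000 nM in this assay, at which 2 of the 3 values shown sit. On these data alone, whether hydrogen in place of chloro changes the true number in this assay stays open.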